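Bromo-hydroxy hydrazone variant of a pyridyl oxadiazole thioether

A few compounds are considered here, and "the series" means these few. Any claim that something is new, unique, unknown or untested is made for them only; others in the source may bear on it.

Measured compounds:
- compound 1 `NNC(=O)CSc1nnc(-c2ccncc2)o1`: 3260 nM
- compound 2 `Cc1ccc(/C=N/NC(=O)CSc2nnc(-c3ccncc3)o2)cc1`: 16800 nM

Both compounds share one core built around a pyridyl oxadiazole thioether; they differ at the far end of the hydrazide arm. In a functional assay on SW 1116 cells (Homo sapiens) for cytotoxicity, read by MTT assay, with a stated time of 48 h (a higher number here means a weaker inhibitor, a lower number a stronger inhibitor), compound 1 gives 3260 nM. In this assay compound 2 gives 16800 nM, the higher of the two numbers, and the gap between them lies beyond the usual scatter, so compound 2 is the weaker inhibitor of this pair.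

Compound 3 `O=C(CSc1nnc(-c2ccncc2)o1)N/N=C/c1cc(Br)ccc1O` has not yet been measured. It is compound 2 with one change: 5-bromo-2-hydroxyphenyl in place of 4-methylphenyl on a carbon with a double bond to nitrogen. Within the data shown here, no measured pair shows this exact change, so the expectation can rest only on the two numbers above.

Because compound 1 gives 3260 nM while compound 2 gives 16800 nM, the end group on the hydrazone clearly matters here, but the direction for compound 3 is not fixed by the data. A modest move toward lower numbers, close to the edge of the scatter, is expected, that is a 1.9-fold lower number from compound 2 to compound 3 (0.27 log units; within the scatter). Compound 3 is expected to give about 9000 nM, within a range from 2500 nM to 30000 nM.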

Compound 3, half-maximal inhibitory concentration: 8150 nM
For compound 3 the middle estimate is 1.1-fold (0.04 log units) above the measured one; low and high end bracket the measured number.
By their numbers in this assay, from the lowest: compound 1; then compound 3; then compound 2.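

In this assay, placing 5-bromo-2-hydroxyphenyl instead of 4-methylphenyl on the carbon with a double bond to nitrogen gives a 2.1-fold lower number from compound 2 to compound 3 (0.31 log units; beyond the scatter). Among these compounds, this is the first comparison in which the hydrazone stays in place and only its aromatic end group changes, so it shows that the substituents on that ring can alter the cytotoxicity read-out on their own, although the shift here is modest. Nothing available explains this shift, and the swap removes the methyl group while adding both a bromine and a hydroxyl group, so the step belongs to the whole exchange rather than to any single atom or group.

The compounds shown leave open whether the bromine, the hydroxyl group or the two together account for the lower number, a question that a ring carrying only one of them, or an unsubstituted phenyl ring, could help to settle. They also leave open how a quite different end group on the hydrazone, such as a carboxylic acid, an amine or a longer alkyl chain, would behave in this assay.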